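The source may hold more compounds than are shown below. What is called first, only, known or untested is meant among the compounds shown, and "the series" means these compounds.

In a functional assay on HeLa cells (Homo sapiens) for inhibition, read by sulforhodamine B assay, with a stated time of 74 h (on this read-out lower numbers stand for stronger inhibition and higher numbers for weaker inhibition), compound 1 `CS(=O)(=O)N1C(=O)COC12C=CC(=O)C=C2`, with methyl on the sulfonyl sulfur, gives 7530 nM. Compound 2 `O=C1C=CC2(C=C1)OCC(=O)N2S(=O)(=O)c1ccccc1` has phenyl in place of that methyl. For compound 2 the assay reports only a limit, > 10000 nM, and not a number. Compound 3 `Cc1ccc(S(=O)(=O)N2C(=O)C(C)OC23C=CC(=O)C=C3)cc1`, whose aromatic ring on the sulfonyl sulfur also carries a group, likewise gives only a limit, > 10000 nM. Compound 2 therefore stands at the limit of > 10000 nM in this assay, at which 2 of the 3 values shown sit.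

The next structure is compound 4 `O=C1C=CC2(C=C1)OCC(=O)N2S(=O)(=O)c1ccc(Cl)cc1`, which is compound 2 with chloro in place of hydrogen on an aromatic carbon, the change from phenyl to 4-chlorophenyl: chloro in place of hydrogen on an aromatic carbon. For the measured compounds named here, the only measured step at this sulfonyl group is an at least 1.3-fold higher number from compound 1 to compound 2 (0.12 log units; that floor lies within the scatter). That step swaps the whole group on the sulfur, so it bears on the new change only loosely. Going by the values given here, no measured step isolates a change on the aromatic ring itself. The expectation in this assay is therefore no step beyond the scatter, with the assay quite possibly again reporting only a limit. The estimated step is a step that the limit leaves unreadable from compound 2 to compound 4. For compound 4 the expected value is 12000 nM, with an estimated range from 5000 nM to 30000 nM.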

Compound 4, half-maximal inhibitory concentration: > 10000 nM
Compound 4 ended at the assay's limit; the forecaster's own chance of this, stated with the estimate: 65%; the middle value is on the limit's open side.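

In this assay, on these data alone, compound 4 gives a limit and not a number, as compound 2 does, so the step between them cannot be read and the effect of chloro in place of hydrogen on this aromatic carbon remains unknown. Compared directly with the methyl group on the sulfonyl sulfur, 4-chlorophenyl gives an at least 1.3-fold higher number from compound 1 to compound 4 (0.12 log units; that floor lies within the scatter), so this second swap of the whole group, like the first, shows no change that can be told apart from the scatter, though a larger rise is not excluded. The new result adds one more compound to those that give no number in this assay, leaving compound 1 as the only compound shown with a measured value: the limit of > 10000 nM in this assay, at which 3 of the 4 values shown sit.

As far as these compounds go, it remains open whether phenyl or 4-chlorophenyl truly weakens inhibition relative to methyl, and how far the true values of compound 2 and compound 4 lie beyond the limit. Also open, from the compounds shown here alone, is whether an amine or a carboxylic acid on the aromatic ring, or a longer chain in place of the methyl of compound 1, would give a number that can be compared.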